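Alkyl variation on the aromatic nitrogen, compound 4

The source may report more compounds than this note shows. Statements on the series, on what has been measured and on what is new or still open speak of the compounds shown alone.

Three compounds share one core and differ only in the group on the aromatic nitrogen. Compound 1 `CCCc1c(OCCCCOc2ccc(-c3nn[nH]n3)cc2)ccc2c1ccn2CCC` gives 652 nM in a functional assay for binding affinity to metabotropic glutamate receptor 2 (Homo sapiens), read by GTPgammaS binding, with a stated time of 1 h, at 30 degrees C; a higher number here means that more compound is needed for the effect, a lower number that less compound is needed. Compound 2 `CCCCCn1ccc2c(CCC)c(OCCCCOc3ccc(-c4nn[nH]n4)cc3)ccc21` gives 598 nM in this assay. Compound 3 `CCCc1c(OCCCCOc2ccc(-c3nn[nH]n3)cc2)ccc2c1ccn2C(C)C` gives 1130 nM in this assay, the highest of the three numbers, though the steps to it, a 1.7-fold higher number from compound 1 to compound 3 (0.24 log units; within the scatter) and a 1.9-fold higher number from compound 2 to compound 3 (0.28 log units; within the scatter), both lie within the scatter; the step of a 1.1-fold lower number from compound 1 to compound 2 (0.04 log units; within the scatter) is likewise within the scatter.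

Compound 4 `CCCc1c(OCCCCOc2ccc(-c3nn[nH]n3)cc2)ccc2c1ccn2CC(C)C` is not yet measured. It differs from compound 3 by isobutyl in place of isopropyl on an aromatic nitrogen. Going by the values given here, the steps that bear on this change are the two already seen at the same nitrogen, from propyl and from pentyl to isopropyl, and neither exceeded the scatter. The step for isobutyl is therefore expected to stay within the scatter as well, a 1.4-fold lower number from compound 3 to compound 4 (0.15 log units; within the scatter), with no direction claimed beyond a slight tendency back toward the numbers of compound 1 and compound 2. Compound 4 is estimated at 800 nM, in the range 400 nM to 1600 nM.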

Compound 4, half-maximal effective concentration: 765 nM
Beside the measured number, compound 4's estimate is 1.0-fold (0.02 log units) above it; the range from low to high includes it.
By their numbers in this assay, from the lowest: compounds 2, 1, 4 and 3 (each within the scatter of the next).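

In this assay, isobutyl is a fourth alkyl group on the aromatic nitrogen, and each of its steps lies within the scatter: (a 1.5-fold lower number from compound 3 to compound 4 (0.17 log units; within the scatter)), (a 1.3-fold higher number from compound 2 to compound 4 (0.11 log units; within the scatter)) and (a 1.2-fold higher number from compound 1 to compound 4 (0.07 log units; within the scatter)). Across propyl, pentyl, isopropyl and isobutyl, no step at this nitrogen exceeds the scatter, so these four compounds separate neither by chain length nor by the exchange of isopropyl for isobutyl. Nothing available bears on why the numbers stay so close.

The compounds shown leave open whether a group of another kind on this nitrogen, such as benzyl, a chain ending in an amine or a chain ending in a carboxylic acid, would give a step beyond the scatter. Also open, going by these compounds, is how the nitrogen bearing hydrogen would compare with these four alkyl compounds.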